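Moving the sulfonyl aryl substituent: a step to compound 4

The compounds below may be only part of what the source reports. "The series", "measured", "known", "first", "only" and "open" are said of these compounds alone.

Compound 1 `O=C(NCc1ccc(CNS(=O)(=O)c2ccc([N+](=O)[O-])cc2)cc1)c1ccc(F)cc1` gives 1000 nM in an assay on MDA-MB-231 cells for binding affinity to C-X-C chemokine receptor type 4 (Homo sapiens), read by fluorescence and microscopy, with stated times of 10 min and 30 min; on this read-out higher numbers stand for an effect only at larger amounts of compound and lower numbers for an effect already at smaller amounts.
Compound 2 `O=C(NCc1ccc(CNS(=O)(=O)c2cccc(Cl)c2)cc1)c1ccc(F)cc1` gives 1 nM in this assay.
Compound 3 `O=C(NCc1ccc(CNS(=O)(=O)c2ccc(Cl)cc2)cc1)c1ccc(F)cc1` gives 100 nM in this assay.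

All three compounds share a core and differ only in the aryl group on the sulfonyl sulfur. Compound 3 stands second highest of the three numbers: it lies a modest step from compound 1, a 10-fold lower number from compound 1 to compound 3 (1.00 log units; beyond the scatter), and a large step from compound 2, a 100-fold higher number from compound 2 to compound 3 (2.00 log units; beyond the scatter).

Compound 4 `Cc1ccccc1S(=O)(=O)NCc1ccc(CNC(=O)c2ccc(F)cc2)cc1` has not yet been measured. Compared with compound 3 the change is 2-methylphenyl in place of 4-chlorophenyl on a sulfonyl sulfur. Among the compounds with values here, no measured pair shows a 2-methylphenyl on a sulfonyl sulfur, so no step bears on it directly. Within the data shown here, two steps bear on it indirectly: where the substituent sits on the aryl ring mattered greatly, a 100-fold higher number from compound 2 to compound 3 (2.00 log units; beyond the scatter), while exchanging one substituent for another at the same place mattered less, a 10-fold lower number from compound 1 to compound 3 (1.00 log units; beyond the scatter). Since both the substituent and its place change here, the direction is uncertain, and the expected range is wide. Compound 4 is expected to give about 30 nM in this assay, between 3 nM and 300 nM, which would mean an estimated step of a 3.3-fold lower number from compound 3 to compound 4 (0.52 log units; beyond the scatter).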

Compound 4, effective concentration (reported as EC, without a stated level of effect): 100 nM
The estimate for compound 4 lay 3.3-fold (0.52 log units) below the measured number; low and high end bracket the measured number.
By their numbers in this assay, from the lowest: compound 2; then compounds 3 and 4 (each within the scatter of the next); then compound 1.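

In this assay, within the data shown here, 2-methylphenyl on a sulfonyl sulfur in place of 4-chlorophenyl gives no change at the digits printed from compound 3 to compound 4 (within the scatter), the first exchange at this position that leaves the number unmoved. Both the substituent and its place on the ring differ in this exchange, so the earlier picture of large shifts at this position does not hold for every change of aryl group. The 3-chlorophenyl group still stands apart, with a 100-fold higher number from compound 2 to compound 4 (2.00 log units; beyond the scatter), while replacing 4-nitrophenyl gives a 10-fold lower number from compound 1 to compound 4 (1.00 log units; beyond the scatter).

Nothing measured here accounts for why these aryl groups give these numbers. Going by these compounds, it remains open whether the low number of compound 2 would survive a methyl in place of its chloro, and how an amine or a carboxylic acid on the aryl ring would read.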